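A few compounds are considered here, and "the series" means these few. Any claim that something is new, unique, unknown or untested is made for them only; others in the source may bear on it.

Compound 1 `c1ccc(Cc2nnc(-c3c[nH]c4ccccc34)o2)cc1` — in a functional assay on LNCaP cells (Homo sapiens) for cytotoxicity, read by MTT assay (on this read-out higher numbers stand for weaker inhibition and lower numbers for stronger inhibition), compound 1 gives > 1000000 nM, a limit of the assay and not a number.
Compound 2 `COc1ccc(-c2nnc(-c3c[nH]c4ccccc34)o2)cc1` — in this assay compound 2 gives > 1000000 nM, again a limit and not a number.
Compound 3 `COc1ccc(-c2nnc(-c3c[nH]c4ccccc34)o2)cc1OC` — in this assay compound 3 gives > 1000000 nM, also a limit and not a number.

All three compounds share one core and differ only in the group carried on the six-membered ring attached to it. On the numbers shown, compound 3 stands at a limit, and the two further values shown are limits as well, so no compound can be placed above or below another. Within the data shown here, the one step between compounds that differ in a single place, a step that the two limits leave unreadable from compound 2 to compound 3, cannot be read in size, since both ends of it are limits; this follows from the limit of > 1000000 nM in this assay, at which 3 of the 3 values shown sit.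

Compound 4 `COc1ccc(-c2nnc(-c3c[nH]c4ccccc34)o2)c(OC)c1OC` is the next compound, not yet measured. It differs from compound 3 by methoxy in place of hydrogen on an aromatic carbon. Among the measured compounds shown here, because the limit of > 1000000 nM in this assay, at which 3 of the 3 values shown sit, holds for every measured value, no measured step gives a size or direction for this change. The expectation is therefore that compound 4 will again be reported as a limit in this assay, with an estimated step of a number no higher from compound 3 to compound 4 (the limit leaves the size open) that is effectively none beyond the scatter. The estimate for compound 4 is 1000000 nM, with a range from 300000 nM to 3000000 nM.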

Compound 4, half-maximal inhibitory concentration: > 1000000 nM
Compound 4 gave a limit, no number; the forecaster's own chance of this, stated with the estimate: 85%; the middle value lies on the limit itself.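

Among these compounds, compound 3 and compound 4 both stand at a limit in this assay and not at a number, so no step between them can be read, in size or in direction: the limit of > 1000000 nM in this assay, at which 4 of the 4 values shown sit.

The compounds shown leave open whether any change to the group on the six-membered ring would give a readable number in this assay.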